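A few compounds are considered here, and "the series" means these few. Any claim that something is new, unique, unknown or untested is made for them only; others in the source may bear on it.

Measured compounds:

compound 1 `CN(C)C(=O)c1cc2cnc(Nc3ccc(C(=O)NCCCCCN=C=S)cc3)nc2n1C1CCCC1`, which in a functional assay on A549 cells (Homo sapiens) for inhibition, read by CCK-8 assay, with a stated time of 72 h, tested at 10 uM (on this read-out higher numbers stand for a stronger effect at the one concentration tested and lower numbers for a weaker effect), gives 100%

compound 2 `CN(C)C(=O)c1cc2cnc(Nc3ccc(C(=O)NCCCCCCN=C=S)cc3)nc2n1C1CCCC1`, which in this assay gives 100%

compound 3 `CN(C)C(=O)c1cc2cnc(Nc3ccc(C(=O)NCCCCCN=C=S)cc3F)nc2n1C1CCCC1`, which in this assay gives 15.6%

Compound 4 `CN(C)C(=O)c1cc2cnc(Nc3ccc(C(=O)NCCCCCCN=C=S)cc3F)nc2n1C1CCCC1` has not yet been measured in this assay.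

Compound 1 and compound 2 differ in one place: a group of 4 heavy atoms (2 carbon, 1 nitrogen, 1 sulfur; no ring) in place of a group of 3 heavy atoms (1 carbon, 1 nitrogen, 1 sulfur; no ring), on a saturated chain carbon, five bonds along the chain from an amide-type nitrogen. That change made a step of no change at the digits printed from compound 1 to compound 2 (within the scatter). The very same change separates compound 3 from compound 4: a group of 4 heavy atoms (2 carbon, 1 nitrogen, 1 sulfur; no ring) in place of a group of 3 heavy atoms (1 carbon, 1 nitrogen, 1 sulfur; no ring), on a saturated chain carbon, five bonds along the chain from an amide-type nitrogen. The place is described in the same words for both pairs, so the change is the same, only made on a different core.

The two cores differ as follows: fluoro in place of hydrogen on an aromatic carbon. That difference made a step of a number 84.4 percentage points lower from compound 1 to compound 3 (beyond the scatter), so the core of compound 3 sits far lower in this assay than the core of compound 1.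

In this assay the step from compound 3 to compound 4 is expected to be small, about as small as no change at the digits printed from compound 1 to compound 2 (within the scatter), and is estimated at a number 1.4 percentage points higher from compound 3 to compound 4 (within the scatter). This rests on a single pair, so it is a loose guide. Compound 4 is therefore expected to give about 17%, with a plausible range from 5% to 35%.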

Compound 4, a percentage reported as inhibition, at one concentration (the size of the read-out at that concentration, not a potency): 22.9%
Beside the measured number, compound 4's estimate is 5.9 percentage points below it, and the stated range covers the measured number.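

In this assay, the new step is a number 7.3 percentage points higher from compound 3 to compound 4 (within the scatter), so the change on the saturated chain carries over from one core to the other with no step beyond the scatter on either: the same change on two cores in this assay, no change at the digits printed (within the scatter) from compound 1 to compound 2 and a number 7.3 percentage points higher (within the scatter) from compound 3 to compound 4, 7.3 percentage points apart, within the scatter of two such steps. The fluoro change also carries over, now giving a number 77.1 percentage points lower from compound 2 to compound 4 (beyond the scatter), and a large loss appears on both chain versions: the same change on two cores in this assay, a number 84.4 percentage points lower (beyond the scatter) from compound 1 to compound 3 and a number 77.1 percentage points lower (beyond the scatter) from compound 2 to compound 4, 7.3 percentage points apart, within the scatter of two such steps. For the compounds shown here, this shows that, for these four compounds, the two changes act much as they did on the first pair, but it rests on only two pairs at one concentration, gives no potency, and does not explain why a single fluoro has so large an effect.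

On these data alone, it remains open whether chloro or methyl on the same aromatic carbon would bring a similar loss. As far as these compounds go, it is also open how a longer chain, or an amine or a carboxylic acid in place of the sulfur-containing group, would behave on either core.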